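The source may report more compounds than this note shows. Statements on the series, on what has been measured and on what is new or still open speak of the compounds shown alone.

Compound 2 `C#CCOC(=O)/C(C)=C/CC/C(C)=C/CC/C(C)=C/CC[C@@H]1[C@@]2(C)CCC(=O)C(C)(C)[C@H]2CC[C@@]1(C)O` carries an ethynyl group on a saturated chain carbon bound to an oxygen next to a carbonyl group. In a functional assay on A549 cells (Homo sapiens) for antiproliferative activity, read by MTT assay, with a stated time of 48 h (a higher number here means a weaker inhibitor, a lower number a stronger inhibitor), compound 2 gives 45100 nM, the higher of the two plain numbers in hand. Compound 1 `C/C(=C\CC/C(C)=C/CC[C@@H]1[C@@]2(C)CCC(=O)C(C)(C)[C@H]2CC[C@@]1(C)O)CC/C=C(\C)C(=O)OCc1cn(C[C@@H]2O[C@H](n3ccc(=O)[nH]c3=O)C[C@H]2O)nn1` gives 28100 nM in this assay, and its gap to compound 2 lies within the scatter. Compound 3 `C/C(=C\CC/C(C)=C/CC[C@@H]1[C@@]2(C)CCC(=O)C(C)(C)[C@H]2CC[C@@]1(C)O)CC/C=C(\C)C(=O)OCc1cn(-c2ccc(Br)cc2)nn1` reaches only a limit of this assay, > 150000 nM. Among the measured compounds shown here, the step of an at least 3.3-fold higher number from compound 2 to compound 3 (0.52 log units; beyond the scatter) is the one measured change that bears on the new compound, and it rests on (the limit of > 150000 nM in this assay, at which 1 of the 3 values shown sits).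

Compound 4 `C/C(=C\CC/C(C)=C/CC[C@@H]1[C@@]2(C)CCC(=O)C(C)(C)[C@H]2CC[C@@]1(C)O)CC/C=C(\C)C(=O)OCc1cn(-c2cccc(F)c2)nn1` differs from compound 2 by 1-(3-fluorophenyl)-1H-1,2,3-triazol-4-yl in place of ethynyl on a saturated chain carbon bound to an oxygen next to a carbonyl group. For the measured compounds named here, the change resembles the one from compound 2 to compound 3, where ethynyl was likewise replaced by a 1-(4-bromophenyl)-1H-1,2,3-triazol-4-yl group at the same place, and that step was at least modest. A step of the same direction and roughly the same size is expected here, a 2.4-fold higher number from compound 2 to compound 4 (0.39 log units; beyond the scatter), with a real chance that this assay once more reports only a limit. Compound 4 is therefore estimated at 110000 nM, between 40000 nM and 300000 nM.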

Compound 4, half-maximal inhibitory concentration: 124000 nM
The estimate for compound 4 lay 1.1-fold (0.05 log units) below the measured number; the range from low to high includes it.
By their numbers in this assay, from the lowest: compounds 1 and 2 (each within the scatter of the next); then compound 4. At a limit, above all of these: compound 3.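

In this assay, the step of a 2.7-fold higher number from compound 2 to compound 4 (0.44 log units; beyond the scatter) puts a real size on replacing ethynyl with an aryl-bearing triazole at this place, whereas the earlier step to compound 3 gave only a floor. Both steps run in the same direction, so compound 3 and compound 4 each sit on the weaker side of compound 2. The two aryl groups cannot be ranked, since the step of an at least 1.2-fold lower number from compound 3 to compound 4 (0.08 log units; that floor lies within the scatter) rests on a limit and not on a number: the limit of > 150000 nM in this assay, at which 1 of the 4 values shown sits.

From the compounds shown here alone, whether 3-fluorophenyl and 4-bromophenyl truly differ on the aromatic nitrogen therefore stays open. Also open, going by these compounds, is whether an amine or a carboxylic acid on the phenyl ring, in place of the fluorine, would bring the number back towards that of compound 2.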